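Changing the Amide Substituent from Compound 3 to Compound 4

A few compounds are considered here, and "the series" means these few. Any claim that something is new, unique, unknown or untested is made for them only; others in the source may bear on it.

Compound 1 `CC(C)(C)c1ccc(C(=O)N2CCC3(CC2)C(=O)N(CC(=O)N2CCCC(C(N)=O)C2)CN3c2ccccc2)cc1` and compound 2 `CC(C)(C)OC(=O)NCCNC(=O)CN1CN(c2ccccc2)C2(CCN(C(=O)c3ccc(C(C)(C)C)cc3)CC2)C1=O` share one core and differ only in the group on a carbonyl carbon. In an assay on HEK293 cells for displacement of a labelled ligand from NPC1-like intracellular cholesterol transporter 1 (Homo sapiens) (a lower number here means a stronger inhibitor, a higher number a weaker inhibitor), compound 1 gives 16900 nM, and compound 2 gives 10900 nM; the step of a 1.6-fold lower number from compound 1 to compound 2 (0.19 log units; within the scatter) lies within the scatter. Compound 3 `COC(=O)CCNC(=O)CN1CN(c2ccccc2)C2(CCN(C(=O)c3ccc(C(C)(C)C)cc3)CC2)C1=O` carries a third variant of that group, but in this assay compound 3 gives "not determined" (no result reported), so compound 3 stands without a number. Compound 4 `CC(C)(C)c1ccc(C(=O)N2CCC3(CC2)C(=O)N(CC(=O)NCNS(C)(=O)=O)CN3c2ccccc2)cc1` differs from compound 3 by methanesulfonamido in place of (methoxycarbonyl)methyl on a saturated chain carbon bound to an amide-type nitrogen. Within the data shown here, the only measured step that bears on such an exchange of the amide substituent is the one from compound 1 to compound 2, and it stayed within the scatter, so no change beyond the scatter is expected here. Compound 4 is therefore estimated at 13000 nM, with a range from 4000 nM to 40000 nM.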

Compound 4, half-maximal inhibitory concentration: 3200 nM
Estimate against measurement, compound 4: 4.1-fold (0.61 log units) above; the measured number lies below the stated range.
By their numbers in this assay, from the lowest: compound 4; then compounds 2 and 1 (each within the scatter of the next).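

In this assay, this amide substituent now moves the number beyond the scatter: ((methanesulfonamido)methyl)amino in place of 3-carbamoylpiperidin-1-yl on a carbonyl carbon gives a 5.3-fold lower number from compound 1 to compound 4 (0.72 log units; beyond the scatter), and methanesulfonamido in place of ((tert-butoxycarbonyl)amino)methyl gives a 3.4-fold lower number from compound 2 to compound 4 (0.53 log units; beyond the scatter). Among these compounds, the earlier step at this position did not leave the scatter, so compound 4 is the first compound here to separate from the others. No measurement shown accounts for this difference. With no number for compound 3, its step to compound 4 cannot be read. As far as these compounds go, whether a longer chain carrying methanesulfonamido, or a carboxylic acid in place of methanesulfonamido, would keep this number stays open.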